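Capping the Acid: From Compound 1 to Compound 3

The source may report more compounds than this note shows. Statements on the series, on what has been measured and on what is new or still open speak of the compounds shown alone.

Compound 1, `CC(C)(C)[Si](C)(C)O[C@@H]1CCCO[C@@H]1COCC(=O)O`, carries a free carboxylic acid. In a functional assay on SW1573 cells (Homo sapiens) for antiproliferative activity, read by sulforhodamine B assay, with a stated time of 48 h (on this read-out lower numbers stand for stronger inhibition of growth and higher numbers for weaker inhibition of growth), compound 1 gives only a limit, > 100000 nM, so its true number is not known. Compound 2, `CC(C)(C)[Si](C)(C)O[C@@H]1CCCO[C@@H]1COCC(=O)OCc1ccccc1`, is its benzyl ester. In this assay compound 2 gives 29000 nM. The step between them, an at least 3.4-fold lower number from compound 1 to compound 2 (0.53 log units; beyond the scatter), has only a lower bound since it rests on (the limit of > 100000 nM in this assay, at which 1 of the 2 values shown sits). Compound 3, `COC(=O)/C=C/OC[C@H]1OCCC[C@H]1O[Si](C)(C)C(C)(C)C`, has not yet been measured. It differs from compound 1 as follows: 2-(methoxycarbonyl)ethenyl in place of carboxymethyl on an oxygen on a saturated carbon. As with compound 2, the free acid becomes an ester, and a lower number is expected because an at least 3.4-fold lower number from compound 1 to compound 2 (0.53 log units; beyond the scatter) went that way. The new ester is smaller than the benzyl one, so the gain is expected to be modest. Compound 3 is therefore expected to give 45000 nM, within a range of 12000 nM to 150000 nM. That estimate amounts to an at least 2.2-fold lower number from compound 1 to compound 3 (0.34 log units; beyond the scatter).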

Compound 3, concentration for 50% growth inhibition: 50000 nM
Compound 3: the middle estimate sits 1.1-fold (0.05 log units) below what was measured; the range from low to high includes it.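

With compound 3, a second ester on this oxygen on a saturated carbon gives a number in this assay, and the entering 2-(methoxycarbonyl)ethenyl, unlike carboxymethyl, has no hydrogen-bond donor. So compound 2 is no longer the only capped acid with a measured number, and its benzyl group is not needed for one. Still, the change itself reads only as an at least 2.0-fold lower number from compound 1 to compound 3 (0.30 log units; that floor lies within the scatter), and that floor cannot establish a real gain, because the comparison rests on a limit: the limit of > 100000 nM in this assay, at which 1 of the 3 values shown sits.

The compounds shown leave open whether the double bond of the new group matters, which a saturated ester chain of the same length would test. They also leave open how an amide or a primary alcohol would read on this same oxygen.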